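Replacing the side chain of compound 1

This account rests on a few compounds, and the source may have more. Where it says the series, first, only, none or still open, it means among the compounds named here.

Going by the values given here, compound 1 (`COc1ccc(N(C)c2nc(C)nc3ccccc23)cc1C(=O)NCC[Se]C#N`) gives 1250 nM in a functional assay on MDA-MB-231 cells (Homo sapiens) for inhibition, read by MTT assay, with a stated time of 48 h (on this read-out lower numbers stand for stronger inhibition and higher numbers for weaker inhibition), and holds the highest of the three numbers so far. Compound 2 (`Cc1nc(N(C)c2ccc(OCC[Se]C#N)cc2)c2ccccc2n1`) gives 317 nM and compound 3 (`Cc1nc(N(C)c2ccc([Se]C#N)c(Cl)c2)c2ccccc2n1`) gives 9 nM in the same test, both lower than compound 1 beyond the scatter. Compound 4 (`COc1ccc(N(C)c2nc(C)nc3ccccc23)cc1OCCCC[Se]C#N`) remains unmeasured and differs from compound 1 by one change (a group of 8 heavy atoms (5 carbon, 1 nitrogen, 1 oxygen, 1 selenium; no ring) in place of a group of 8 heavy atoms (4 carbon, 2 nitrogen, 1 oxygen, 1 selenium; no ring), on an aromatic carbon). Among the compounds with values here, no measured pair isolates this change. Compound 2, whose chain also attaches through oxygen, stands at 317 nM and suggests a moderately lower number. The expected change is a modest fall (a 2.5-fold lower number from compound 1 to compound 4 (0.40 log units; beyond the scatter)) in this assay and could stay small. For compound 4 the estimated value is 500 nM within an expected range of 150 nM to 1600 nM on this measure.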

Compound 4, half-maximal inhibitory concentration: 1350 nM
The estimate for compound 4 lay 2.7-fold (0.43 log units) below the measured number; the measured number falls inside the stated range.
By their numbers in this assay, from the lowest: compound 3; then compound 2; then compounds 1 and 4 (each within the scatter of the next).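

In this assay, the exchange on the aromatic carbon ortho to a methoxy group gives a 1.1-fold higher number from compound 1 to compound 4 (0.03 log units; within the scatter). At this position, then, a group with a hydrogen-bond donor and a double bond and one with neither, of equal heavy-atom count, cannot be told apart by this read-out. Nothing at hand accounts for this.

Going by these compounds, compounds 2 and 3 differ from compound 1 in more than one place, and what sets their lower numbers stays open. On these data alone, whether a shorter chain or an amine linking the chain to this carbon would shift the number also stays open.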